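The source may report more compounds than this note shows. Statements on the series, on what has been measured and on what is new or still open speak of the compounds shown alone.

The three measured compounds share one core and differ only in the group carried on the sulfur and, for one of them, in the pyrazole substitution. Compound 1 `Cc1cc(Nc2cc(-c3ccccc3)[nH]n2)n2nc(SCCCc3ccccc3)nc2n1` gives 6510 nM in a functional assay on MGC-803 cells (Homo sapiens) for inhibition, read by MTT assay, with a stated time of 72 h; on this read-out higher numbers stand for weaker inhibition and lower numbers for stronger inhibition. Compound 2 `Cc1cc(Nc2ccn(Cc3cccc4ccccc34)n2)n2nc(SCc3ccc(Br)cc3)nc2n1` gives 3240 nM in this assay. Compound 3 `Cc1cc(Nc2cc(-c3ccccc3)[nH]n2)n2nc(SCc3ccc([N+](=O)[O-])cc3)nc2n1` gives 4250 nM in this assay, which places it second highest of the three numbers; its nearest neighbour is compound 2 and its furthest is compound 1, and both gaps fall within the scatter. For the measured compounds named here, the one step that touches the sulfur-bound group, a 1.5-fold lower number from compound 1 to compound 3 (0.19 log units; within the scatter), did not reach beyond the scatter either.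

Compound 4 `Cc1ccc(CSc2nc3nc(C)cc(Nc4cc(-c5ccccc5)[nH]n4)n3n2)cc1` is the next compound and is not yet measured. It differs from compound 3 in one place: methyl in place of nitro on an aromatic carbon. Going by the values given here, no measured pair isolates a swap of the group on that aromatic carbon, so the only guidance is the general flatness of the series and the small size of the step from compound 1 to compound 3. On that basis no step beyond the scatter is expected from compound 3 to compound 4 in this assay, the expected step being a 1.0-fold lower number from compound 3 to compound 4 (0.01 log units; within the scatter). Compound 4 is therefore estimated at 4200 nM, with a range from 1500 nM to 12000 nM.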

Compound 4, half-maximal inhibitory concentration: 6960 nM
For compound 4 the middle estimate is 1.7-fold (0.22 log units) below the measured one, and the stated range covers the measured number.
By their numbers in this assay, from the lowest: compounds 2, 3, 1 and 4 (each within the scatter of the next, the first and the last beyond it).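

Swapping nitro for methyl on an aromatic carbon of a six-membered aromatic ring of carbon only, para to a large group, gives a 1.6-fold higher number from compound 3 to compound 4 (0.21 log units; within the scatter) in this assay, so this first isolated change at that position stays within the scatter even though the leaving nitro carries hydrogen-bond acceptors and the entering methyl carries none. The other new comparison, a 1.1-fold higher number from compound 1 to compound 4 (0.03 log units; within the scatter), likewise stays within the scatter, and with a 1.5-fold lower number from compound 1 to compound 3 (0.19 log units; within the scatter) it means that 4-methylphenyl, 4-nitrophenyl and phenethyl in that part of the sulfur-bound group cannot be told apart in this assay on the phenyl-bearing pyrazole. No measurement of any property of these compounds bears on this result.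

From the compounds shown here alone, whether an amine, a carboxylic acid or a methoxy group on the same aromatic carbon would produce a step beyond the scatter remains open, as does whether a longer chain between the sulfur and the ring would do so. The bromine of compound 2 offers no answer to this, since compound 2 also differs from compound 3 and compound 4 in the pyrazole substitution.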